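The source may hold more compounds than are shown below. What is called first, only, known or untested is meant among the compounds shown, and "the series" means these compounds.

Two compounds share one core and differ only in the group on a carbonyl carbon. Compound 1 `CN(C)CCCN(C)C(=O)Nc1cc2c(Nc3ccc(F)c(Cl)c3)ncnc2cc1O[C@H]1CCOC1` carries a (3-(dimethylamino)propyl)(methyl)amino group there, and in a functional assay on A-431 cells (Homo sapiens) for antiproliferative activity, read by sulforhodamine B assay, with a stated time of 72 h (a lower number here means a stronger inhibitor, a higher number a weaker inhibitor), compound 1 gives 200 nM. Compound 2 `O=C(Nc1cc2c(Nc3ccc(F)c(Cl)c3)ncnc2cc1O[C@H]1CCOC1)N1CC(O)C1` carries a 3-hydroxyazetidin-1-yl group instead, and in this assay compound 2 gives 1930 nM. Within the data shown here, the one step measured, a 9.7-fold higher number from compound 1 to compound 2 (0.98 log units; beyond the scatter), shows that swapping this group can move the number well beyond the scatter, and it leaves compound 2 with the highest of the two numbers. Compound 3 `CN1CCN(C(=O)Nc2cc3c(Nc4ccc(F)c(Cl)c4)ncnc3cc2O[C@H]2CCOC2)CC1` makes a further swap at the same place: 4-methylpiperazin-1-yl in place of 3-hydroxyazetidin-1-yl on a carbonyl carbon. Among the measured compounds shown here, no measured step covers this pair, so the expectation rests on the single step from compound 1 to compound 2 and is uncertain. For compound 3 the estimate is 450 nM, with a range of 130 nM to 1500 nM, a step of a 4.3-fold lower number from compound 2 to compound 3 (0.63 log units; beyond the scatter) expected to bring the number back toward that of compound 1.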

Compound 3, half-maximal inhibitory concentration: 675 nM
Estimate against measurement, compound 3: 1.5-fold (0.18 log units) below; low and high end bracket the measured number.
By their numbers in this assay, from the lowest: compound 1; then compound 3; then compound 2.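

In this assay, the group on the carbonyl carbon now gives three clearly separated results rather than a single contrast. Replacing 3-hydroxyazetidin-1-yl with 4-methylpiperazin-1-yl gives a 2.9-fold lower number from compound 2 to compound 3 (0.46 log units; beyond the scatter), so the two ring groups are not interchangeable, yet the piperazine does not fully recover the number of the open-chain compound, as the change from that chain shows: a 3.4-fold higher number from compound 1 to compound 3 (0.53 log units; beyond the scatter). Nothing shown here explains why these groups differ.

As far as these compounds go, the step from compound 2 to compound 3 changes ring size, the hydroxyl and the number of ring nitrogens together, so their separate contributions remain unknown. A 4-hydroxypiperidin-1-yl group, which pairs a six-membered ring with a hydroxyl, would help separate ring size from the hydroxyl.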